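From 3-Chloro-4-fluorophenyl to 3,5-Dichlorophenyl

A few compounds are considered here, and "the series" means these few. Any claim that something is new, unique, unknown or untested is made for them only; others in the source may bear on it.

In a functional assay on A549 cells (Homo sapiens) for antiproliferative activity, read by MTT assay, with a stated time of 48 h (on this read-out higher numbers stand for weaker inhibition and lower numbers for stronger inhibition), compound 2 (`O=C(/C=C/c1ccccc1)Nc1cc2c(Nc3ccc(F)c(Cl)c3)ncnc2s1`) gives 11200 nM as its reading. Compound 3 (`N#Cc1cccc(Nc2ncnc3cc(NC(=O)/C=C/c4ccccc4)sc23)c1`) gives 17200 nM on the same read-out, which lies within the scatter of the reading for compound 2. Compound 1 (`C#Cc1cccc(Nc2ncnc3cc(NC(=O)/C=C/c4ccccc4)sc23)c1`) gives 26200 nM as its reading, a higher number than that of compound 2 and one beyond the scatter.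

Compound 4 (`O=C(/C=C/c1ccccc1)Nc1cc2c(Nc3cc(Cl)cc(Cl)c3)ncnc2s1`) has not yet been measured. It differs from compound 2 in one place: 3,5-dichlorophenyl in place of 3-chloro-4-fluorophenyl on a nitrogen on an aromatic ring. For the measured compounds named here, no measured pair makes this exchange, so the evidence for it is indirect. Going by the values given here, the only measured single-place step is a 1.5-fold lower number from compound 1 to compound 3 (0.18 log units; within the scatter), and it replaces ethynyl with cyano on an aromatic carbon. That step shows one substituent exchange on an aromatic ring that leaves the number within the scatter, but it says nothing directly about moving from one halogen pattern to the other.

On this limited basis, no step beyond the scatter is expected in this assay. The estimated step is a 1.1-fold higher number from compound 2 to compound 4 (0.03 log units; within the scatter) and is expected to stay small. For compound 4 the estimated value is 12000 nM, with an expected range from 5000 nM to 28000 nM as the likely span.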

Compound 4, half-maximal inhibitory concentration: 40 nM
Compound 4: the middle estimate sits 300-fold (2.48 log units) above what was measured; measured number below the stated range.
By their numbers in this assay, from the lowest: compound 4; then compounds 2, 3 and 1 (each within the scatter of the next, the first and the last beyond it).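

In this assay, putting 3,5-dichlorophenyl in place of 3-chloro-4-fluorophenyl on a nitrogen on an aromatic ring gives a 280-fold lower number from compound 2 to compound 4 (2.45 log units; beyond the scatter), so this place on the shared core can move the reading by far more than the scatter. The only earlier single-place step, a 1.5-fold lower number from compound 1 to compound 3 (0.18 log units; within the scatter), had shown no such movement, and it involved a different exchange, so it gave no sign that this nitrogen substituent could matter so much. The new step arises although the group that leaves and the group that enters have the same count of heavy atoms and both hold one six-membered aromatic ring of carbon only, but nothing measured here accounts for its size.

The compounds shown leave open whether the step belongs to the second chlorine, to the 3,5-dichlorophenyl pattern as a whole or to the loss of fluorine, and a bromine, a methyl or a methoxy group in place of the chlorines would bear on this. They also leave open whether the step would persist if the phenyl of the amide side chain carried an amine or a carboxylic acid.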